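Bromo in place of methoxy: notes on growth inhibition

A few compounds are considered here, and "the series" means these few. Any claim that something is new, unique, unknown or untested is made for them only; others in the source may bear on it.

Measured in a functional assay on A549 cells (Homo sapiens) for inhibition, read by MTT assay, with a stated time of 24 h; a lower number here means a stronger inhibitor of growth, a higher number a weaker inhibitor of growth:
- compound 1 `Cn1cc(-c2nc3ccccc3n2C(=O)c2ccccc2Br)c2ccccc21` gives 43200 nM
- compound 2 `COc1cccc(C(=O)n2c(-c3cn(C)c4ccc(OC)cc34)nc3ccccc32)c1` gives 4600 nM
- compound 3 `COc1ccc2c(c1)c(-c1nc3ccccc3n1C(=O)c1cc(OC)c(OC)c(OC)c1)cn2C` gives 2400 nM

Compound 2 (4600 nM) lies within the scatter of compound 3 (2400 nM), while compound 1 (43200 nM) stands well above compound 2, beyond the scatter.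

Compound 4 `COc1ccc2c(c1)c(-c1nc3ccccc3n1C(=O)c1cccc(Br)c1)cn2C` departs from compound 2 at a single place, meta to a large group: bromo in place of methoxy on an aromatic carbon. In words, this is bromo in place of methoxy on an aromatic carbon. Among the measured compounds shown here, no measured pair isolates this change, so its size in this assay remains unseen. For the measured compounds named here, compound 1 is the only measured bromo compound, and its high value (43200 nM) suggests a modest move toward a higher number, although it differs from compound 2 in more than one place. The expected change, probably close to the scatter, is a 1.4-fold higher number from compound 2 to compound 4 (0.15 log units; within the scatter), toward a weaker inhibitor of growth. Compound 4 is estimated at 6500 nM (expected range 2000 nM to 20000 nM).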

Compound 4, concentration for 50% growth inhibition: 24800 nM
Compound 4: the middle estimate sits 3.8-fold (0.58 log units) below what was measured, and the stated range ends below it.
By their numbers in this assay, from the lowest: compounds 3 and 2 (each within the scatter of the next); then compounds 4 and 1 (each within the scatter of the next).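

In this assay, among the compounds shown here, this is the first step that isolates a single change: a 5.4-fold higher number from compound 2 to compound 4 (0.73 log units; beyond the scatter). Going from 3-methoxyphenyl to 3-bromophenyl therefore moves the number beyond the scatter, toward a weaker inhibitor of growth, so this aromatic carbon does respond to the group it carries. Nothing at hand gives a reason for the size or direction of this step.

The compounds shown leave open whether the step reflects the loss of methoxy or the arrival of bromo; a chloro, a fluoro, an amine or a carboxylic acid on the same aromatic carbon would help separate the two. Also open, on these data alone, is whether the same exchange gives a step of similar size on a different core.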